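Aryl swap on the saturated ring carbon: cytotoxicity notes

A few compounds are considered here, and "the series" means these few. Any claim that something is new, unique, unknown or untested is made for them only; others in the source may bear on it.

The two measured compounds share a core and differ only in their aryl substituents. Compound 1 `O=C1CSC(N2N=C(c3ccc(Cl)c(Cl)c3)CC2c2ccccc2Cl)=N1` and compound 2 `Cc1cccc(C2CC(c3ccc(C)c(C)c3)=NN2C2=NC(=O)CS2)c1` have both been run in an ADME assay on RAW264.7 cells (Mus musculus) for cytotoxicity, read by MTT assay, with a stated time of 24 h; a lower number here means that less compound is tolerated, a higher number that more compound is tolerated. In this assay compound 1 gives 143000 nM, while compound 2 gives 237000 nM. Compound 1 has the lowest of the two numbers, but the nearest number, that of compound 2, lies within the scatter of it, so no order between the two can be stated from these data.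

Compound 3 `O=C1CSC(N2N=C(c3ccc(Cl)c(Cl)c3)CC2c2ccc(F)cc2)=N1` has not yet been measured in this assay. It differs from compound 1 in one place: 4-fluorophenyl in place of 2-chlorophenyl on a saturated ring carbon. Going by the values given here, no measured pair shows the effect of this change, and the two numbers known so far sit close together. The step is therefore expected to be small, with no direction beyond the scatter: a 1.0-fold higher number from compound 1 to compound 3 (0.02 log units; within the scatter). Compound 3 is expected to give 150000 nM in this assay, with an estimated range from 60000 nM to 350000 nM.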

Compound 3, half-maximal cytotoxic concentration: 139000 nM
Estimate against measurement, compound 3: 1.1-fold (0.03 log units) above; low and high end bracket the measured number.
By their numbers in this assay, from the lowest: compounds 3, 1 and 2 (each within the scatter of the next).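

In this assay, going by these compounds alone, the first pair that isolates this position gives a 1.0-fold lower number from compound 1 to compound 3 (0.01 log units; within the scatter) and so the two values cannot be told apart. Within the data shown here, the swap of 2-chlorophenyl for 4-fluorophenyl on the saturated ring carbon changes both the halogen and its place on the phenyl ring, yet with the 3,4-dichlorophenyl group and the rest of the core of compound 1 held constant it produces no readable difference in the cytotoxicity read-out, which is the first direct information on this carbon and on this change. No measurement on these compounds offers an explanation for this result.

Since both features of the aryl group change together in this one pair, the compounds shown cannot separate the contribution of the halogen from that of its place on the ring, and a single step cannot show whether other aryl groups on this carbon would behave alike. Also open, as far as these compounds go, is whether a phenyl ring carrying an amine or a carboxylic acid, or a longer alkyl chain in place of the aryl group, would stay within the same range.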